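A Rearranged Bicyclic Group: Expectations for Compound 4

This account rests on a few compounds, and the source may have more. Where it says the series, first, only, none or still open, it means among the compounds named here.

Compound 1 `CCOC(=O)C1=C(Nc2ccccc2)S/C(=C\c2ccc(O)c(O)c2)C1=O`: 48.7%
Compound 2 `CCOC(=O)C1=C(Nc2ccccc2)S/C(=C\c2ccc(OC)cc2)C1=O`: 32.9%
Compound 3 `CCOC(=O)C1=C(Nc2ccccc2)S/C(=C\c2cc3cccnc3[nH]2)C1=O`: 54.3%

In a functional assay on JAR cells (Homo sapiens) for inhibition, read by MTT assay, with a stated time of 72 h, tested at 10 uM (on this read-out lower numbers stand for less inhibition and higher numbers for more inhibition at the one concentration tested (going by the name of the read-out)), compound 3 gives the highest of the three numbers, though one of its two gaps, a number 5.6 percentage points higher from compound 1 to compound 3 (within the scatter), is within the scatter; only the other, a number 21.4 percentage points higher from compound 2 to compound 3 (beyond the scatter), is beyond it. Compound 4 `CCOC(=O)C1=C(Nc2ccccc2)S/C(=C\c2cc3ncccc3[nH]2)C1=O` keeps the same atoms as compound 3 joined differently: a group of 9 heavy atoms (7 carbon, 2 nitrogen; one five-membered aromatic ring with 1 hetero atom, one six-membered aromatic ring with 1 hetero atom) in place of a group of 9 heavy atoms (7 carbon, 2 nitrogen; one five-membered aromatic ring with 1 hetero atom, one six-membered aromatic ring with 1 hetero atom), on a double-bonded chain carbon bound to a double-bonded ring carbon. Within the data shown here, no measured step rearranges a group this way; the steps of a number 5.6 percentage points higher from compound 1 to compound 3 (within the scatter) and a number 21.4 percentage points higher from compound 2 to compound 3 (beyond the scatter) only show that this bicyclic group compares well with the phenyl groups. A step within the scatter is therefore expected for compound 4, a number 4.3 percentage points lower from compound 3 to compound 4 (within the scatter). Compound 4 is estimated at 50%, between 30% and 70%.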

Compound 4, a percentage reported as inhibition, at one concentration (the size of the read-out at that concentration, not a potency): 74.8%
The estimate for compound 4 lay 24.8 percentage points below the measured number; measured number outside the range, above it.
By their numbers in this assay, from the lowest: compound 2; then compounds 1 and 3 (each within the scatter of the next); then compound 4.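

In this assay the same atoms joined differently on the bicyclic group make a change beyond the scatter at this place (a number 20.5 percentage points higher from compound 3 to compound 4 (beyond the scatter)). Compound 4 also stands clear of both phenyl compounds (a number 26.1 percentage points higher from compound 1 to compound 4 (beyond the scatter); a number 41.9 percentage points higher from compound 2 to compound 4 (beyond the scatter)), whereas compound 3 could not be told apart from compound 1. Nothing available explains the difference between the two arrangements.

The compounds shown leave open whether an amine or a carboxylic acid on the bicyclic group would keep this number. They also leave open whether the rearrangement would give a similar step on a different core.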